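The compounds below may be only part of what the source reports. "The series", "measured", "known", "first", "only" and "open" are said of these compounds alone.

Measured so far:
Compound 1 `C[C@@H]1CN(c2nccc3[nH]c(-c4ccc(F)c(F)c4)nc23)C[C@H](C)N1C`: 50000 nM
Compound 2 `CN1CCC(N2CCN(c3nccc4[nH]c(-c5ccc(F)c(F)c5)nc34)CC2)CC1`: 200000 nM
Compound 3 `CN1CCN(CC2CCN(c3nccc4[nH]c(-c5ccc(F)c(Cl)c5)nc34)CC2)CC1`: 155000 nM

All three were tested in a physicochemical assay for solubility, read by HPLC, using the shake flask method, in phosphate buffer, with a stated time of 20 h, at pH 6.5; on this read-out lower numbers stand for lower solubility and higher numbers for higher solubility. Compound 3 gives the second highest of the three numbers, within the usual scatter of compound 2 and beyond the scatter above compound 1. Compound 4 `CN1CCN(CC2CCN(c3nccc4[nH]c(-c5cccc(C(=O)O)c5)nc34)CC2)CC1` carries 3-carboxyphenyl in place of 3-chloro-4-fluorophenyl on an aromatic carbon. Going by the values given here, no measured pair shows this exchange, so the expectation rests only on the spread from compound 1 at 50000 nM to compound 2 at 200000 nM, and it stays loose. The expected change is a small rise that stays within the scatter, a 1.6-fold higher number from compound 3 to compound 4 (0.21 log units; within the scatter). Compound 4 is estimated at 250000 nM, with an expected range of 90000 nM to 700000 nM.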

Compound 4, solubility: 195000 nM
Compound 4: the middle estimate sits 1.3-fold (0.11 log units) above what was measured, within the range that was stated.
By their numbers in this assay, from the lowest: compound 1; then compounds 3, 4 and 2 (each within the scatter of the next).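

In this assay, going by these compounds alone, this is the first exchange that can be read in one place: on an aromatic carbon between two ring nitrogen atoms, 3-carboxyphenyl replacing 3-chloro-4-fluorophenyl gives a 1.3-fold higher number from compound 3 to compound 4 (0.10 log units; within the scatter) and so cannot be told from no change. This position therefore takes two quite different rings, one with a hydrogen-bond donor and one without, and the read-out does not separate them. Nothing at hand gives a reason for this. As far as these compounds go, whether an amide or a nitrile on this phenyl ring would read the same stays open. So does whether the exchange would read the same with the other amine groups of compound 1 and compound 2.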